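The source may hold more compounds than are shown below. What is called first, only, known or untested is meant among the compounds shown, and "the series" means these compounds.

In an ADME assay on RAW264.7 cells (Mus musculus) for cytotoxicity, read by neutral red uptake, with a stated time of 24 h (on this read-out higher numbers stand for lower toxicity in this test and lower numbers for higher toxicity in this test), compound 2 (`CC(C(=O)NOCc1ccccc1)N1C(=O)S/C(=C\c2ccccc2)C1=O`) gives > 128000 nM, a limit of the assay and not a number. Compound 1 (`O=C(CN1C(=O)S/C(=C\c2ccccc2)C1=O)NOCc1ccccc1`) gives > 128000 nM, also a limit. Compound 3 (`C=CCONC(=O)C(C)N1C(=O)S/C(=C\c2ccccc2)C1=O`) gives > 128000 nM, again a limit. The measured steps are a step that the two limits leave unreadable from compound 1 to compound 2 and a step that the two limits leave unreadable from compound 2 to compound 3. Compound 4 (`CC(C(=O)NOCc1ccccc1)N1C(=O)S/C(=C\c2ccc(F)cc2)C1=O`) differs from compound 2 by fluoro in place of hydrogen on an aromatic carbon. Neither measured step involves this change, and neither has a size to carry over. Because of the limit of > 128000 nM in this assay, at which 3 of the 3 values shown sit, compound 2 offers only a limit as its starting point, so no change beyond the scatter is expected, in either direction. The estimated step is a number no higher from compound 2 to compound 4 (the limit leaves the size open). For compound 4 the expected value is 128000 nM, with an estimated range from 64000 nM to 256000 nM.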

Compound 4, half-maximal cytotoxic concentration: > 128000 nM
Compound 4 gave a limit, no number; the forecaster's own chance of this, stated with the estimate: 80%; the middle value sits exactly at the limit.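

No step can be read between compound 2 and compound 4, because each gives only a limit and not a number: the limit of > 128000 nM in this assay, at which 4 of the 4 values shown sit.

The compounds shown leave open what size the change from phenyl to 4-fluorophenyl has, and at what concentration any of these compounds would reach half-maximal cytotoxicity.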